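From Chloro to Iodo: A Small Halogen Step

This account rests on a few compounds, and the source may have more. Where it says the series, first, only, none or still open, it means among the compounds named here.

Of the compounds shown here, three sharing one core have been measured in a functional assay on HEK293 cells for agonist activity at probable G-protein coupled receptor 27 (Homo sapiens), read by a luciferase reporter and beta-arrestin recruitment, with a stated time of 10 min; on this read-out lower numbers stand for smaller maximal responses and higher numbers for larger maximal responses. Compound 1 `O=C(Nc1ccc(S(=O)(=O)Nc2ccccc2)cc1)c1ccc(Br)cc1F` gives 67%. Compound 2 `N#Cc1ccc(C(=O)Nc2ccc(S(=O)(=O)Nc3ccccc3)cc2)c(F)c1` gives 29%, and compound 3 `O=C(Nc1ccc(S(=O)(=O)Nc2ccccc2)cc1)c1ccc(Cl)cc1F` gives 57%. Compound 3 therefore stands second highest of the three: the difference a number 10 percentage points lower from compound 1 to compound 3 (within the scatter) lies within the scatter, so compounds 1 and 3 cannot be told apart, while the step of a number 28 percentage points higher from compound 2 to compound 3 (beyond the scatter) lies beyond it, and the step of a number 38 percentage points lower from compound 1 to compound 2 (beyond the scatter) is the largest of all.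

Compound 4 `O=C(Nc1ccc(S(=O)(=O)Nc2ccccc2)cc1)c1ccc(I)cc1F` has not yet been measured. It differs from compound 3 in one place: iodo in place of chloro on an aromatic carbon. Cut one bond further out, the change reads 4-chloro-2-fluorophenyl to 2-fluoro-4-iodophenyl.

The step that bears most directly on this change is the exchange of one halogen for another between compound 1 and compound 3, which gave a number 10 percentage points lower from compound 1 to compound 3 (within the scatter), a change within the scatter. The large drop a number 38 percentage points lower from compound 1 to compound 2 (beyond the scatter) concerns a cyano group and is less informative here. Compound 4 is thus expected to lie close to compounds 1 and 3, with the estimated step of a number 7 percentage points higher from compound 3 to compound 4 (within the scatter) remaining within the usual scatter. Compound 4 is estimated to give 64%, with a range from 48% to 80%.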

Compound 4, largest response reached (Emax), in percent of the reference or control that the assay uses: 36%
For compound 4 the middle estimate is 28 percentage points above the measured one; the whole stated range lies above it.
By their numbers in this assay, from the lowest: compounds 2 and 4 (each within the scatter of the next); then compounds 3 and 1 (each within the scatter of the next).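

Exchanging one halogen for another at this position is not always a quiet change. The earlier exchange of bromo for chloro stayed within the scatter, yet iodo in place of chloro gives a number 21 percentage points lower from compound 3 to compound 4 (beyond the scatter) and iodo in place of bromo gives a number 31 percentage points lower from compound 1 to compound 4 (beyond the scatter), while the step to the nitrile-bearing compound, a number 7 percentage points higher from compound 2 to compound 4 (within the scatter), leaves the iodo and nitrile compounds indistinguishable, so the maximal response does not change evenly from chloro through bromo to iodo among these compounds. No measurement is available that accounts for this separation of iodo from chloro and bromo.

The four compounds all carry a halogen or a nitrile at this position, so they leave open how the response would change with a methyl group, a methoxy group, an amine or a carboxylic acid in that place. Going by these compounds, they also share the fluoro group and the rest of the core, so it remains open whether iodo would have the same effect on the response without that fluoro group or on a different core.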